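The source may hold more compounds than are shown below. What is called first, only, known or untested is meant among the compounds shown, and "the series" means these compounds.

In a functional assay on MDA-MB-231 cells (Homo sapiens) for inhibition, read by MTT assay, with a stated time of 72 h (on this read-out higher numbers stand for weaker inhibition and lower numbers for stronger inhibition), compound 2 `Nc1nc2cc(-c3nn(CCC(=O)NO)c4ncnc(N)c34)ccc2o1` gives > 50000 nM, which is a limit and not a number. This is the limit of > 50000 nM in this assay, at which 1 of the 3 values shown sits. Compound 3 `Nc1nc2cc(-c3nn(CCCCCCCCC(=O)NO)c4ncnc(N)c34)ccc2o1` gives 30300 nM, and compound 1 `Nc1ncnc2c1c(-c1cnc3[nH]ccc3c1)nn2CCCCCCCCCC(=O)NO`, which has a different group on the core, gives 10100 nM. Compound 4 `Nc1nc2cc(-c3nn(CC(=O)NO)c4ncnc(N)c34)ccc2o1` has a shorter chain than compound 2: hydroxycarbamoyl in place of (hydroxycarbamoyl)methyl on a saturated chain carbon bound to an aromatic nitrogen, with hydroxycarbamoyl in place of (hydroxycarbamoyl)methyl on a saturated chain carbon bound to an aromatic nitrogen. Within the data shown here, the one measured change of this chain is an at least 1.6-fold lower number from compound 2 to compound 3 (0.21 log units; that floor lies within the scatter), and it goes towards a longer chain. No change beyond the scatter is therefore expected in this assay. The estimated change is a number no higher from compound 2 to compound 4 (the limit leaves the size open). For compound 4 the expected value is 50000 nM, within an estimated range of 25000 nM to 100000 nM.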

Compound 4, half-maximal inhibitory concentration: 6310 nM
Compound 4: middle estimate off by 7.9-fold (0.90 log units), on the high side, outside the stated range (below it).
By their numbers in this assay, from the lowest: compounds 4 and 1 (each within the scatter of the next); then compound 3. At a limit, above all of these: compound 2.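

In this assay, replacing 2-(hydroxycarbamoyl)ethyl with (hydroxycarbamoyl)methyl gives an at least 7.9-fold lower number from compound 2 to compound 4 (0.89 log units; beyond the scatter), the first step along this chain that clearly exceeds the scatter. The chain on the aromatic nitrogen therefore matters, and the shortest chain shown, not a longer one, gives the clear drop from compound 2. The value for compound 2 is a limit and not a number, so the full size of the step stays unknown: the limit of > 50000 nM in this assay, at which 1 of the 4 values shown sits.

Still open, as far as these compounds go, is how a 4-(hydroxycarbamoyl)butyl chain would behave on the shared core. Also open, from the compounds shown here alone, is whether a carboxylic acid in place of the hydroxycarbamoyl of compound 4 would keep its value.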